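The compounds below may be only part of what the source reports. "The series", "measured", "known", "first", "only" and "open" are said of these compounds alone.

Measured in a functional assay on MCF7 cells (Homo sapiens) for cytotoxicity, read by MTT assay, with a stated time of 72 h; on this read-out higher numbers stand for weaker inhibition and lower numbers for stronger inhibition:
compound 1 `COc1ccc(/C=C2\CCC/C(=C\c3cccc(OC)c3OC)C2=O)cc1OC`: 6500 nM
compound 2 `COc1cccc(/C=C2\CCC/C(=C\c3ccc(OC)c(OC)c3)C2=O)c1`: 4600 nM
compound 3 `COc1cc(/C=C2\CCC/C(=C\c3ccc(OC)c(OC)c3)C2=O)cc(OC)c1`: 3900 nM

Compound 2 gives the second highest number of the three in this assay; its nearest neighbour is compound 3 (a 1.2-fold lower number from compound 2 to compound 3 (0.07 log units; within the scatter)) and its furthest is compound 1 (a 1.4-fold lower number from compound 1 to compound 2 (0.15 log units; within the scatter)). Both gaps sit within the scatter, so on these numbers the three compounds are not separated from one another.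

Compound 4 `COc1cc(/C=C2\CCC/C(=C\c3ccc(OC)c(OC)c3)C2=O)ccc1O` differs from compound 2 by hydroxy in place of hydrogen on an aromatic carbon. Cut one bond further out, the difference reads 3-methoxyphenyl to 4-hydroxy-3-methoxyphenyl.

Among the measured compounds shown here, no measured step adds or removes a hydroxy. The two steps in hand, a 1.4-fold lower number from compound 1 to compound 2 (0.15 log units; within the scatter) and a 1.2-fold lower number from compound 2 to compound 3 (0.07 log units; within the scatter), each exchange hydrogen and methoxy on an aromatic carbon, and each stays within the scatter. They bear on the present step only in showing that a single substituent change on these aryl rings has so far left the number in this assay where it was. No step beyond the scatter is therefore expected here, and no direction is claimed. For compound 4 the expected step is a 1.3-fold lower number from compound 2 to compound 4 (0.12 log units; within the scatter). The estimate for compound 4 in this assay is 3500 nM, with a range from 1200 nM to 10000 nM.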

Compound 4, half-maximal inhibitory concentration: 7900 nM
Compound 4: middle estimate off by 2.3-fold (0.35 log units), on the low side, within the range that was stated.
By their numbers in this assay, from the lowest: compounds 3, 2, 1 and 4 (each within the scatter of the next, the first and the last beyond it).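

In this assay, the change from 3-methoxyphenyl to 4-hydroxy-3-methoxyphenyl gives a step (a 1.7-fold higher number from compound 2 to compound 4 (0.23 log units; within the scatter)) that leaves compound 4 not separated from compound 2. The earlier steps shown here only exchanged hydrogen and methoxy, whereas this one shows that a hydroxy, with its hydrogen-bond donor, on an aromatic carbon ortho to a methoxy group and para to a large group also stays within the scatter, so this position shows no measurable sensitivity to this single change. No measurement on hand accounts for the size or direction of this step, so it stands as an observation without an explanation.

Still open, going by these compounds, is whether the same carbon would stay within the scatter when carrying a different group, such as an amine, a carboxylic acid or a longer alkoxy chain, since a single hydroxy step cannot show how far this position tolerates change. Also open, on these data alone, is whether a hydroxy on the other aryl ring of the shared core would give a step of similar size, and whether the result would carry over to any cell line other than this one.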